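A few compounds are considered here, and "the series" means these few. Any claim that something is new, unique, unknown or untested is made for them only; others in the source may bear on it.

Compound 2 `C=CCN(C)C(=O)c1ccc(C(CC)(CC)c2ccc(OCCC(O)(CC)CC)c(C)c2)n1CC` stands at the weak end of the three measured compounds. In an assay on cells for agonist activity at vitamin D3 receptor (Homo sapiens), with a stated time of 96 h (on this read-out higher numbers stand for an effect only at larger amounts of compound and lower numbers for an effect already at smaller amounts), compound 2 gives > 10000 nM, which is a limit of the assay and not a number; the limit of > 10000 nM in this assay, at which 1 of the 3 values shown sits, marks this value as such. Compound 1 `CCn1c(C(=O)NCCN(C)C)ccc1C(CC)(CC)c1ccc(OCCC(O)(CC)CC)c(C)c1`, carrying the same core with a (2-(dimethylamino)ethyl)amino group on the carbonyl carbon, gives 82 nM in this assay. Compound 3 `CCn1c(C(=O)Nc2cccc(C(F)(F)F)c2)ccc1C(CC)(CC)c1ccc(OCCC(O)(CC)CC)c(C)c1` gives 5900 nM in this assay. Among the compounds with values here, the steps that bear on the present change are an at least 120-fold higher number from compound 1 to compound 2 (2.08 log units; beyond the scatter) and an at least 1.6-fold lower number from compound 2 to compound 3 (0.22 log units; that floor lies within the scatter): the first is large, the second a floor that lies within the scatter.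

Compound 4 `CCn1c(C(=O)N(C)CC(=O)O)ccc1C(CC)(CC)c1ccc(OCCC(O)(CC)CC)c(C)c1` differs from compound 2 by carboxy in place of vinyl on a saturated chain carbon bound to an amide-type nitrogen. Within the data shown here, no measured step exchanges a carboxy for a vinyl, so the two recorded steps only frame where compound 2 sits. The expectation for compound 4 is therefore a step of a number no higher from compound 2 to compound 4 (the limit leaves the size open), with a good chance that this assay again reports only a limit. Compound 4 is estimated at 10000 nM, within a range from 2000 nM to 30000 nM.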

Compound 4, half-maximal effective concentration: 89 nM
Compound 4: middle estimate off by 110-fold (2.05 log units), on the high side, and the stated range ends above it.
By their numbers in this assay, from the lowest: compounds 1 and 4 (each within the scatter of the next); then compound 3. At a limit, above all of these: compound 2.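

The value of compound 2 in this assay is a limit of the assay and not a number: the limit of > 10000 nM in this assay, at which 1 of the 4 values shown sits. Carboxy in place of vinyl gives an at least 110-fold lower number from compound 2 to compound 4 (2.05 log units; beyond the scatter), and since compound 4 keeps the methyl on the amide-type nitrogen, that methyl does not by itself go with the weak read-out of compound 2. The remaining comparisons give a 1.1-fold higher number from compound 1 to compound 4 (0.04 log units; within the scatter), and a 66-fold lower number from compound 3 to compound 4 (1.82 log units; beyond the scatter), so at this carbonyl carbon a chain ending in carboxy and one ending in dimethylamino cannot be told apart, while the 3-(trifluoromethyl)phenyl amide stays well off both.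

The compounds shown leave open how a methyl ester or a primary amide in place of the carboxy would read. They also leave open whether a longer chain carrying the carboxy, or a hydrogen in place of the methyl, would keep this value.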